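From pyridin-2-yl to 4-chloropyridin-2-yl

The compounds below may be only part of what the source reports. "The series", "measured", "known", "first", "only" and "open" are said of these compounds alone.

In a functional assay on MDA-MB-231 cells (Homo sapiens) for inhibition, read by CCK-8 assay, with a stated time of 48 h (on this read-out lower numbers stand for stronger inhibition of growth and higher numbers for weaker inhibition of growth), compound 1 (`Cc1ccccc1Nc1nc(NCc2ccco2)ncc1Cl`) gives > 100000 nM, which is a limit and not a number. Among the measured compounds shown here, compound 2 (`Cc1ccccc1Nc1nc(Nc2ccccn2)ncc1Cl`) gives 11200 nM, the only true number so far. For the measured compounds named here, the one measured step is an at least 8.9-fold lower number from compound 1 to compound 2 (0.95 log units; beyond the scatter), and it brought in the pyridin-2-yl group. Compound 3 (`Cc1ccccc1Nc1nc(Nc2cc(Cl)ccn2)ncc1Cl`) keeps that group and changes it: chloro in place of hydrogen on an aromatic carbon. The step to compound 2, an at least 8.9-fold lower number from compound 1 to compound 2 (0.95 log units; beyond the scatter), swapped a whole group and so offers only a loose guide to a single added chloro. A small shift toward a lower number in this assay is therefore expected, and it may not clear the scatter. The estimated change is a 1.7-fold lower number from compound 2 to compound 3 (0.24 log units; within the scatter). For compound 3 the estimated value is 6500 nM, with an expected range from 2000 nM to 21000 nM.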

Compound 3, concentration for 50% growth inhibition: 52400 nM
Beside the measured number, compound 3's estimate is 8.1-fold (0.91 log units) below it; the measured number lies above the stated range.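

Among the compounds shown here, at this position, on the aromatic carbon opposite the ring nitrogen, chloro in place of hydrogen gives a 4.7-fold higher number from compound 2 to compound 3 (0.67 log units; beyond the scatter) in this assay, which shows that a substituent here can weaken growth inhibition, something the earlier compounds, with nothing on this ring, could not show. Set against compound 1, the 4-chloropyridin-2-yl group gives an at least 1.9-fold lower number from compound 1 to compound 3 (0.28 log units; that floor lies within the scatter), so the step cannot be read as a firm gain. Compound 1 stands at a limit, which is not a number: the limit of > 100000 nM in this assay, at which 1 of the 3 values shown sits.

From the compounds shown here alone, whether a fluoro, a methyl or an amine on this same carbon would follow chloro remains open, as does whether chloro on another carbon of the ring would give the same step. The values also leave the cause of the step open.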